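Chloromethyl for vinyl on the carbonyl, two cores

The source may hold more compounds than are shown below. What is called first, only, known or untested is meant among the compounds shown, and "the series" means these compounds.

Compound 1 `C=CC(=O)Nc1ccc(Cn2nc(-c3ccc(Oc4ccccc4)cc3)cc2C(=O)O)cc1` in a functional assay on JeKo-1 cells (Homo sapiens) for inhibition, read by luminescence and CellTiter-Glo, with a stated time of 72 h (on this read-out higher numbers stand for weaker inhibition and lower numbers for stronger inhibition), gives only a limit of the assay, > 60000 nM, not a number. Compound 2 `O=C(CCl)Nc1ccc(Cn2nc(-c3ccc(Oc4ccccc4)cc3)cc2C(=O)O)cc1` in this assay gives 2500 nM. The change between them is chloromethyl in place of vinyl on a carbonyl carbon, and the step is an at least 24-fold lower number from compound 1 to compound 2 (1.38 log units; beyond the scatter), with the value of compound 1 sitting at the assay limit (the limit of > 60000 nM in this assay, at which 1 of the 3 values shown sits). Compound 3 `C=CC(=O)N1CCCC(n2nc(-c3ccc(Oc4ccccc4)cc3)cc2C(=O)OCC)C1` in this assay gives 21200 nM; the difference between the core of compound 3 and the core of compound 1 is not broken down here. Compound 4 `CCOC(=O)c1cc(-c2ccc(Oc3ccccc3)cc2)nn1C1CCCN(C(=O)CCl)C1` is not yet measured and differs from compound 3 by chloromethyl in place of vinyl on a carbonyl carbon. This is the same kind of change, not the same: here the place is a carbonyl carbon whose other neighbours are an amide-type nitrogen in a ring, there an amide-type nitrogen. Resting on an at least 24-fold lower number from compound 1 to compound 2 (1.38 log units; beyond the scatter), a step of a 14-fold lower number from compound 3 to compound 4 (1.15 log units; beyond the scatter) is expected. Compound 4 is estimated at 1500 nM, between 300 nM and 8000 nM.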

Compound 4, half-maximal inhibitory concentration: 800 nM
Compound 4: the middle estimate sits 1.9-fold (0.27 log units) above what was measured; low and high end bracket the measured number.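

Chloromethyl in place of vinyl on a carbonyl carbon gives a 27-fold lower number from compound 3 to compound 4 (1.42 log units; beyond the scatter) in this assay, and the step on the other core points the same way: the same change on two cores in this assay, an at least 24-fold lower number (1.38 log units; beyond the scatter) from compound 1 to compound 2 and a 27-fold lower number (1.42 log units; beyond the scatter) from compound 3 to compound 4; the limit leaves it open whether they differ

Compound 1 gives a limit and not a number: the limit of > 60000 nM in this assay, at which 1 of the 4 values shown sits.

The direction of the change therefore holds on these two cores, while whether its size is the same stays unsettled, and nothing here speaks for any further core.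

Open, on these data alone, is whether bromomethyl or a longer chain in that place on the carbonyl carbon goes the same way as chloromethyl. Also open, as far as these compounds go, is whether an amide in place of the ethyl ester of compound 3 would leave the step as it stands.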